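Swapping the Triazole Substituent for a Dichlorobenzyl Group

A few compounds are considered here, and "the series" means these few. Any claim that something is new, unique, unknown or untested is made for them only; others in the source may bear on it.

The series shares one core, shown in compound 1 `Cc1ccc(-n2cc(COc3cccc4cnc(Nc5cccc(Cl)c5)nc34)nn2)c([N+](=O)[O-])c1` and compound 2 `COc1cccc(-n2cc(COc3cccc4cnc(Nc5cccc(Cl)c5)nc34)nn2)c1`, and differs only in the group carried by the aromatic nitrogen of the triazole. In a functional assay on HCT-116 cells (Homo sapiens) for cytotoxicity, read by cell counting, with a stated time of 48 h (a lower number here means a stronger inhibitor, a higher number a weaker inhibitor), compound 1 reaches only the limit of the assay, > 25000 nM. In this assay compound 2 gives 23000 nM. The change between them amounts to an at least 1.0-fold lower number from compound 1 to compound 2 (0.03 log units; that floor lies within the scatter), so the two stand at the weak end of the scale together, as the limit of > 25000 nM in this assay, at which 1 of the 2 values shown sits, also shows.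

Compound 3 `Clc1cccc(Nc2ncc3cccc(OCc4cn(Cc5c(Cl)cccc5Cl)nn4)c3n2)c1` follows the same position: 2,6-dichlorobenzyl in place of 4-methyl-2-nitrophenyl on an aromatic nitrogen. Among the compounds with values here, the step from compound 1 to compound 2 is the only measured step at that nitrogen, and it showed no movement beyond the scatter. Within the data shown here, a benzyl group in place of an aryl group has no measured counterpart here, so the expectation rests on compound 1 and compound 2 alone. Compound 3 is therefore expected to remain weak, with a step of an at least 1.2-fold lower number from compound 1 to compound 3 (0.09 log units; that floor lies within the scatter), and its estimated value in this assay is 20000 nM, ranging from 4000 nM to 25000 nM.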

Compound 3, half-maximal inhibitory concentration: 24000 nM
Compound 3: middle estimate off by 1.2-fold (0.08 log units), on the low side, within the range that was stated.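

Compound 3 extends the picture at this nitrogen from aryl groups to a benzyl group, and the change of group type brings no separation in this assay: the comparison with the 3-methoxyphenyl group gives a 1.0-fold higher number from compound 2 to compound 3 (0.02 log units; within the scatter). The comparison with the 4-methyl-2-nitrophenyl group, where compound 1 is known only as a limit, gives an at least 1.0-fold lower number from compound 1 to compound 3 (0.01 log units; that floor lies within the scatter), so that the nitro-bearing group, the methoxy-bearing group and the 2,6-dichlorobenzyl group cannot be told apart in this read-out, even though the 2,6-dichlorobenzyl group carries no hydrogen-bond acceptors and the group it replaces carries them. All three compounds thus stay together at the weak end of the scale, close to the point where the assay stops giving numbers, which leaves little room to rank groups at this position: the limit of > 25000 nM in this assay, at which 1 of the 3 values shown sits.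

Whether any group on this nitrogen can bring the value well down remains open, since a group carrying an amine or a carboxylic acid, an unsubstituted benzyl group or a longer alkyl chain does not appear among the compounds shown. On these data alone, it also remains open whether the weak values belong to this position at all or to the shared core of compound 1.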